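This account rests on a few compounds, and the source may have more. Where it says the series, first, only, none or still open, it means among the compounds named here.

Measured so far in a functional assay on A549 cells (Homo sapiens) for inhibition, read by sulforhodamine B assay, with a stated time of 48 h, tested at 50 uM; a higher number here means more inhibition of growth at the concentration tested, a lower number less inhibition of growth:

- compound 1 `COc1ccc([C@@H]2C/C(=N/OCc3cn(-c4ccc(C(=O)c5ccccc5)cc4)nn3)c3cc(CC=C(C)C)c(OC)cc3O2)cc1`: 34%
- compound 2 `COc1cc2c(cc1CC1OC1(C)C)C(=O)C[C@@H](c1ccc(O)cc1)O2`: 79%
- compound 3 `COc1cc2c(cc1CC=C(C)C)/C(=N/NC(N)=O)C[C@@H](c1ccc(O)cc1)O2`: 77%

Compound 1 is the lowest of the three, and the gaps up to compound 2 and compound 3 both lie beyond the scatter. The values of compound 2 and compound 3 lie within the scatter of each other.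

Next is compound 4 `COc1ccc([C@@H]2C/C(=N/OCc3cn(-c4ccc(NC(C)=O)cc4)nn3)c3cc(CC=C(C)C)c(OC)cc3O2)cc1`, which carries acetamido in place of benzoyl on an aromatic carbon, para to a large group: acetamido in place of benzoyl on an aromatic carbon.

Among the measured compounds shown here, no measured pair differs in one place only, so the data give no direct size for this change. For the measured compounds named here, the only guide is indirect: the smaller compound 2 gives 79% and the smaller compound 3 gives 77%, so a swap that leaves a smaller group is expected to move upward, though only part of the way. The expected change is a moderate rise a number 14 percentage points higher from compound 1 to compound 4 (beyond the scatter), with a real chance that it stays within the scatter. For compound 4 the estimated value is 48% (expected range 28% to 70%).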

Compound 4, percent growth inhibition at one concentration: 19%
The estimate for compound 4 lay 29 percentage points above the measured number; the whole stated range lies above it.
By their numbers in this assay, from the lowest: compound 4; then compound 1; then compounds 3 and 2 (each within the scatter of the next).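

In this assay, among the compounds shown here, acetamido in place of benzoyl on the aromatic carbon para to a large group gives the first direct reading at this position, a number a number 15 percentage points lower from compound 1 to compound 4 (beyond the scatter). Within this pair, the smaller group, which has no ring and adds a hydrogen-bond donor, goes with less growth inhibition, so a smaller group here does not by itself bring a gain. No available measurement bears on what lies behind this step.

This single pair cannot separate the loss of the benzoyl ring from the arrival of the amide hydrogen. The compounds shown leave open how an acetyl group, a plain phenyl ring or a free amine on the same aromatic carbon would read in this assay.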